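Trifluoromethyl for methylsulfanyl on the shared core

The source may report more compounds than this note shows. Statements on the series, on what has been measured and on what is new or still open speak of the compounds shown alone.

Measured so far:
compound 1 `CSc1ccnc(NCc2ccc(CNc3ncc(F)cn3)cc2)n1` gives 1 nM
compound 2 `Fc1cnc(NCc2ccc(CNc3ncc(F)cn3)cc2)nc1` gives 1 nM

For the measured compounds named here, in an assay on MDA-MB-231 cells for displacement of a labelled ligand from C-X-C chemokine receptor type 4 (Homo sapiens) (on this read-out lower numbers stand for an effect already at smaller amounts and higher numbers for an effect only at larger amounts of compound), compound 1 gives 1 nM and stands level with compound 2, the only neighbour, with a step of no change at the digits printed from compound 1 to compound 2 (within the scatter). Compound 3 `Fc1cnc(NCc2ccc(CNc3nccc(C(F)(F)F)n3)cc2)nc1` differs from compound 1 by trifluoromethyl in place of methylsulfanyl on an aromatic carbon. Going by the values given here, the single measured step exchanged the whole group bearing methylsulfanyl and was flat, so it bears only loosely on the present change; no step beyond the scatter is expected in this assay, though the uncertainty is wide. For compound 3 the expected value is 2 nM (range 0.5 nM to 8 nM), an expected step of a 2.0-fold higher number from compound 1 to compound 3 (0.30 log units; within the scatter).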

Compound 3, effective concentration (reported as EC, without a stated level of effect): 1 nM
The estimate for compound 3 lay 2.0-fold (0.30 log units) above the measured number; the range from low to high includes it.
By their numbers in this assay, from the lowest: compounds 1, 2 and 3 (each within the scatter of the next).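

In this assay, trifluoromethyl in place of methylsulfanyl on this aromatic carbon gives no change at the digits printed from compound 1 to compound 3 (within the scatter). The earlier step exchanged the whole group bearing methylsulfanyl, whereas this one changes only the substituent, so this position holds its value with either group. No available evidence bears on why the step is flat.

On these data alone, whether an amine, a carboxylic acid or a longer chain on this carbon would hold the value remains open. So does whether a bare hydrogen there would do the same.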